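The source may report more compounds than this note shows. Statements on the series, on what has been measured and on what is new or still open speak of the compounds shown alone.

Measured so far:
- compound 2, `CC(C)n1cnc2c(Nc3ccccc3)nc(NCOCc3ccc(/C=C/C(=O)Nc4ccccc4N)cc3)nc21`: 41%
- compound 1, `CCCCn1cnc2c(Nc3cccc(Cl)c3)nc(NCOCc3ccc(/C=C/C(=O)Nc4ccccc4N)cc3)nc21`: 25.7%

Both compounds share a core and were tested in a functional assay on NCI-H460 cells (Homo sapiens) for antiproliferative activity, read by CCK-8 assay, with a stated time of 72 h, tested at 2 uM; a lower number here means a weaker effect, a higher number a stronger effect of the compound at the concentration tested. Compound 2 stands highest of the two numbers; compound 1 sits a good deal lower, and that gap is beyond the usual scatter of the method. The two differ in more than one place, so their values alone cannot be tied to any single change.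

Compound 3, `CCCCn1cnc2c(Nc3ccccc3)nc(NCOCc3ccc(/C=C/C(=O)Nc4ccccc4N)cc3)nc21`, has not yet been measured in this assay. It differs from compound 2 in one place: butyl in place of isopropyl on an aromatic nitrogen. Among the compounds with values here, the only other compound that carries a butyl group, compound 1, also carries a chloro group on its anilino ring and gives 25.7%, so it is not a clean guide for this step.

For compound 3 a modest step downward from compound 2 is expected, about the size of the scatter, a number 8 percentage points lower from compound 2 to compound 3 (within the scatter). Compound 3 is therefore estimated to give 33% in this assay, with a range from 16% to 50%.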

Compound 3, a percentage reported as inhibition, at one concentration (the size of the read-out at that concentration, not a potency): 23.1%
Compound 3: the middle estimate sits 9.9 percentage points above what was measured; the range from low to high includes it.
By their numbers in this assay, from the lowest: compounds 3 and 1 (each within the scatter of the next); then compound 2.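

In this assay the change from isopropyl to butyl on an aromatic nitrogen can now be read on its own, and it gives a number 17.9 percentage points lower from compound 2 to compound 3 (beyond the scatter) as its step, so this position responds to a change of one alkyl group for another. The chloro group, which clouded the earlier comparison with butyl, can also be read alone: hydrogen in place of chloro on an aromatic carbon gives a number 2.6 percentage points lower from compound 1 to compound 3 (within the scatter) as its step, so with butyl on the nitrogen, this change makes no difference beyond the scatter. No measurement among these data explains why the change on the nitrogen has this size.

From the compounds shown here alone, only isopropyl and butyl appear at this nitrogen, so it remains open how an ethyl group, a cyclopentyl ring or a chain ending in an amine would compare with them. Also open, going by these compounds, is whether chloro on the aromatic carbon would likewise leave the number within the scatter if isopropyl, rather than butyl, sat on the nitrogen.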